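Chloro to methyl exchange carried onto a second core

A few compounds are considered here, and "the series" means these few. Any claim that something is new, unique, unknown or untested is made for them only; others in the source may bear on it.

Of the compounds shown here, three have been measured in a functional assay on the whole organism for positive allosteric modulation, with Rattus norvegicus as the target; on this read-out lower numbers stand for an effect already at smaller amounts and higher numbers for an effect only at larger amounts of compound. Compound 1 `Cc1nn(C)c2c1C(c1cccc(Cl)c1)=NCCN2` gives 0.63 mg/kg. Compound 3 `Cc1cccc(C2=NCCNc3c2c(C)nn3C)c1` gives 2.5 mg/kg. Compound 2 `Cc1nn(C)c2c1C(c1cccc(Cl)c1)=NC(C)(C)CN2` gives 2.5 mg/kg; compound 2 and compound 3 stand level at the digits read, and together they hold the high end of the three numbers. How the core of compound 2 differs from the core of compound 1 is not broken down here.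

The change between compound 1 and compound 3 is methyl in place of chloro on an aromatic carbon. Measured in this assay, this change gives a 4.0-fold higher number from compound 1 to compound 3 (0.60 log units; beyond the scatter). Compound 4 `Cc1cccc(C2=NC(C)(C)CNc3c2c(C)nn3C)c1`, not yet measured, carries the corresponding change on the core of compound 2: methyl in place of chloro on an aromatic carbon. The place is described in identical words for both pairs, so the change is taken as the same. Among the compounds with values here, only this single earlier step is available as a guide, and nothing shows whether the core of compound 2 passes it on unchanged. The expected step in this assay is a 4.0-fold higher number from compound 2 to compound 4 (0.60 log units; beyond the scatter), resting on a 4.0-fold higher number from compound 1 to compound 3 (0.60 log units; beyond the scatter) alone. Compound 4 is accordingly estimated at 10 mg/kg, with a range from 4 mg/kg to 25 mg/kg.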

Compound 4, minimum effective dose: > 10 mg/kg
Compound 4: no number, only a limit (the forecaster's own chance of this, stated with the estimate: 20%); the middle value sits exactly at the limit.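

On the core of compound 2, the exchange of 3-chlorophenyl for 3-methylphenyl in this assay gives an at least 4.0-fold higher number from compound 2 to compound 4 (0.60 log units; beyond the scatter), so the direction seen on the core of compound 1 recurs on a second core: the same change on two cores in this assay, a 4.0-fold higher number (0.60 log units; beyond the scatter) from compound 1 to compound 3 and an at least 4.0-fold higher number (0.60 log units; beyond the scatter) from compound 2 to compound 4; the limit leaves it open whether they differ

For compound 4 the read-out > 10 mg/kg is a limit of the assay and not a number: the limit of > 10 mg/kg in this assay, at which 1 of the 4 values shown sits.

Going by these compounds, the two pairs therefore agree in direction, but the full size of the step on the core of compound 2 remains unknown, and two pairs do not establish a rule for the whole series.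

The compounds shown carry only chloro and methyl at this place, so it remains open how fluoro, methoxy, a nitrile or an amine there would read out on either core. On these data alone, it also remains open whether the same exchange gives a higher number on any core beyond these two.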